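The source may hold more compounds than are shown below. What is called first, only, known or untested is meant among the compounds shown, and "the series" means these compounds.

Working notes on the chalcone series in an assay on isolated protein for inhibition of DNA topoisomerase 1 (Homo sapiens), tested at 100 uM; a higher number here means a stronger effect of the compound at the concentration tested, a lower number a weaker effect.

Compound 1 `O=C(/C=C/c1ccc(N2CCCC2)cc1)c1ccc([N+](=O)[O-])cc1` gives 91.1% in this assay, the highest of the three numbers in hand. Compound 3 `COc1ccc(C(=O)/C=C/c2ccc(F)cc2)c(O)c1` gives 81.2%, which lies within the scatter of compound 1, so no order between compound 1 and compound 3 is claimed. Compound 2 `COc1cc(O)ccc1/C=C/C(=O)c1ccc(N)cc1` gives 0.8%, far below compound 1 and well beyond the scatter. Among the compounds with values here, no two of the measured compounds differ in a single place, so no step between measured compounds is available.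

Compound 4 `O=C(/C=C/c1ccc(N2CCCC2)cc1)c1ccc(O)cc1` has not yet been measured. It differs from compound 1 by hydroxy in place of nitro on an aromatic carbon. Within the data shown here, compound 2, which carries an amine on the ring bearing the carbonyl, is the only compound with a hydrogen-bond donor at that position, but it also differs elsewhere, so its value of 0.8% is only a loose pointer. The step in this assay is expected to run downward and beyond the scatter. For compound 4 the estimate is 55%, within a range of 15% to 90%, which means an expected step of a number 36.1 percentage points lower from compound 1 to compound 4 (beyond the scatter).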

Compound 4, a percentage reported as inhibition, at one concentration (the size of the read-out at that concentration, not a potency): 74.7%
Estimate against measurement, compound 4: 19.7 percentage points below, within the range that was stated.
By their numbers in this assay, from the lowest: compound 2; then compounds 4, 3 and 1 (each within the scatter of the next, the first and the last beyond it).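

In this assay, within the data shown here, the exchange of nitro for hydroxy on an aromatic carbon, para to a large group, gives a number 16.4 percentage points lower from compound 1 to compound 4 (beyond the scatter) and is the first reading at this position from a change in one place. Nitro is therefore not required for a substantial read-out on the core of compound 1: with hydroxy on that carbon, compound 4 still gives 74.7% at the single concentration tested. No measurement in hand bears on what lies behind this step.

From the compounds shown here alone, whether the step follows from the loss of nitro or from the entry of hydroxy stays open, since one pair cannot separate the two. Going by these compounds, how an amine, a methoxy group or a carboxylic acid on the same carbon would read also remains unknown.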